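From urea to amide in a weakly active series

A few compounds are considered here, and "the series" means these few. Any claim that something is new, unique, unknown or untested is made for them only; others in the source may bear on it.

All four compounds here were examined in a functional assay on MCF7 cells (Homo sapiens) for antiproliferative activity, with a stated time of 48 h; on this read-out higher numbers stand for weaker inhibition and lower numbers for stronger inhibition. Compound 1 `O=C(NCCCCl)Nc1ccc(I)cc1` reaches only the limit of > 100000 nM, which is not a number. Compound 3 `CCCCC(O)c1cccc(NC(=O)NC(=O)CC)c1` likewise gives just the limit of > 100000 nM. Among the measured compounds shown here, compound 2 `CC(C)(C)c1ccc(NC(=O)NCCCCl)cc1` is the single compound with a measured number, and in this assay compound 2 gives 49000 nM, so it stands as the only fixed point among the values shown. For the measured compounds named here, the step of an at least 2.0-fold lower number from compound 1 to compound 2 (0.30 log units; that floor lies within the scatter) is the one comparison that can be counted at all, and it rests on a limit, as the limit of > 100000 nM in this assay, at which 2 of the 3 values shown sit, shows. Compound 4 `CC(C)(C)c1ccc(NC(=O)CCCCl)cc1` has not yet been measured. It differs from compound 2 in one place: 3-chloropropyl in place of (3-chloropropyl)amino on a carbonyl carbon. Going by the values given here, no measured step involves a change of this kind, so nothing among the known values points in a direction. Among the compounds with values here, compound 2 already sits close to the limit, and with no guidance the expected step, a 1.4-fold higher number from compound 2 to compound 4 (0.15 log units; within the scatter), is small and lies within the scatter. For compound 4 the expected value is therefore 70000 nM, with a range from 20000 nM to 200000 nM, and a fair chance that only the limit is reported.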

Compound 4, half-maximal inhibitory concentration: > 100000 nM
Compound 4: only a limit was reported; the forecaster's own chance of this, stated with the estimate: 45%; at least 1.4-fold (0.15 log units) between middle value and limit.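

In this assay compound 4 gives > 100000 nM, which is a limit and not a number. Among the compounds shown here, this is the first look at the carbonyl carbon of the urea: putting 3-chloropropyl in place of (3-chloropropyl)amino, which turns the urea into an amide and removes the hydrogen-bond donor of the leaving group, gives an at least 2.0-fold higher number from compound 2 to compound 4 (0.30 log units; that floor lies within the scatter), so the swap brings no measurable gain, though this floor alone cannot show that the change costs activity. Compound 2 therefore remains the only fixed point, and the series now rests almost entirely on a ceiling of the assay: the limit of > 100000 nM in this assay, at which 3 of the 4 values shown sit.

The compounds shown leave open whether a longer chain or a 3-aminopropyl group in this place on the carbonyl carbon would give a real number rather than another limit. They also leave open how far compound 4 truly lies from compound 2, since only a floor on that gap can be stated and it does not clear the usual scatter of repeated measurements.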